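This account rests on a few compounds, and the source may have more. Where it says the series, first, only, none or still open, it means among the compounds named here.

Among the compounds with values here, in a functional assay on MDA-MB-468 cells (Homo sapiens) for inhibition, read by sulforhodamine B assay, with a stated time of 48 h, tested at 10 uM (on this read-out higher numbers stand for more inhibition at the one concentration tested (going by the name of the read-out) and lower numbers for less inhibition), compound 2 `Fc1ccc(-c2cn3ccnc3c(-c3ccc4ncn(C5CCCCC5)c4c3)n2)cc1` gives 19.5%, the lower of the two numbers known so far; compound 1 `Brc1cn2ccnc2c(-c2ccc3ncn(C4CCCCC4)c3c2)n1` gives 44.4%. Within the data shown here, the single measured step, a number 24.9 percentage points lower from compound 1 to compound 2 (beyond the scatter), came from putting 4-fluorophenyl in place of bromo on an aromatic carbon. Compound 3 `CC(=O)c1ccc(-c2cn3ccnc3c(-c3ccc4ncn(C5CCCCC5)c4c3)n2)cc1` has not yet been measured. It differs from compound 2 by acetyl in place of fluoro on an aromatic carbon, so the 4-fluorophenyl that the measured step introduced becomes 4-acetylphenyl. That is a different kind of change from the measured one, so the measured step bears on it only loosely: it shows that the read-out at this site can move by a modest amount, but not in which direction an acetyl would push it. A small step in either direction, or none beyond the scatter, is therefore expected. The estimate for compound 3 in this assay is 25%, with a range from 5% to 50%. This estimate corresponds to an expected step of a number 5.5 percentage points higher from compound 2 to compound 3 (within the scatter).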

Compound 3, a percentage reported as inhibition, at one concentration (the size of the read-out at that concentration, not a potency): 0.73%
Beside the measured number, compound 3's estimate is 24.3 percentage points above it; the whole stated range lies above it.
By their numbers in this assay, from the lowest: compound 3; then compound 2; then compound 1.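

In this assay, acetyl in place of fluoro on the aromatic carbon para to a large group gives a number 18.8 percentage points lower from compound 2 to compound 3 (beyond the scatter) and so shows that the read-out responds to the group carried on this phenyl ring, not only to the exchange of bromo for an aryl group. Measured against the bromo compound, 4-acetylphenyl gives a number 43.7 percentage points lower from compound 1 to compound 3 (beyond the scatter) and thus lies further down than 4-fluorophenyl, so both aryl replacements of bromo shown here lower the read-out, by clearly different amounts. No independent data are available to explain this drop.

The compounds shown leave open whether the drop is particular to acetyl or would also appear with an amine or a carboxylic acid at this place. They also leave open whether a longer chain ending in the same carbonyl would read like compound 3 or like compound 2.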